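The source may report more compounds than this note shows. Statements on the series, on what has been measured and on what is new or still open speak of the compounds shown alone.

Compound 3 `CCn1c(C(=O)NCCCO)ccc1C(CC)(CC)c1ccc(OCS(=O)(=O)c2ccccc2)c(C)c1` gives 42000 nM in a functional assay on MCF7 cells (Homo sapiens) for antiproliferative activity, read by MTT assay, with a stated time of 24 h (on this read-out higher numbers stand for weaker inhibition and lower numbers for stronger inhibition), the highest of the three numbers measured in this series. Compound 1 `CCn1c(C(=O)NCCN)ccc1C(CC)(CC)c1ccc(OCS(=O)(=O)c2ccccc2)c(C)c1` gives 6470 nM in this assay, and compound 2 `CCn1c(C(=O)N[C@@H](C)CO)ccc1C(CC)(CC)c1ccc(OCS(=O)(=O)c2ccccc2)c(C)c1` gives 10800 nM. Both steps that lead to compound 3 read beyond the scatter: a 6.5-fold higher number from compound 1 to compound 3 (0.81 log units; beyond the scatter) and a 3.9-fold higher number from compound 2 to compound 3 (0.59 log units; beyond the scatter), whereas a 1.7-fold higher number from compound 1 to compound 2 (0.22 log units; within the scatter). Compound 4 `CCn1c(C(=O)N[C@@H](C(=O)O)C(C)C)ccc1C(CC)(CC)c1ccc(OCS(=O)(=O)c2ccccc2)c(C)c1` has not yet been measured in this assay. It differs from compound 3 by 1-carboxy-2-methylpropyl in place of 3-hydroxypropyl on an amide-type nitrogen. Of the measured steps, the one that bears most on this change is a 3.9-fold higher number from compound 2 to compound 3 (0.59 log units; beyond the scatter). There the 1-(hydroxymethyl)ethyl group gave the lower number and the 3-hydroxypropyl group the higher one; compound 4 again replaces 3-hydroxypropyl on the amide-type nitrogen. For the measured compounds named here, no measured compound carries a carboxy group, so that part of the change has no precedent here, and the estimate is correspondingly uncertain. On balance he expects a modest step toward a lower number, a 2.8-fold lower number from compound 3 to compound 4 (0.45 log units; beyond the scatter), but one that could fall anywhere from within the scatter to a somewhat larger gain. Compound 4 is therefore estimated to give 15000 nM in this assay, with a range from 4000 nM to 60000 nM.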

Compound 4, half-maximal inhibitory concentration: 44700 nM
For compound 4 the middle estimate is 3.0-fold (0.47 log units) below the measured one, within the range that was stated.
By their numbers in this assay, from the lowest: compounds 1 and 2 (each within the scatter of the next); then compounds 3 and 4 (each within the scatter of the next).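

In this assay, putting 1-carboxy-2-methylpropyl in place of 3-hydroxypropyl on the amide-type nitrogen leaves the result within the scatter, with a 1.1-fold higher number from compound 3 to compound 4 (0.03 log units; within the scatter), so the first carboxy group seen at this position brings no separation from compound 3. The gaps to the other two compounds remain beyond the scatter, with a 4.1-fold higher number from compound 2 to compound 4 (0.62 log units; beyond the scatter) and a 6.9-fold higher number from compound 1 to compound 4 (0.84 log units; beyond the scatter), so 2-aminoethyl and 1-(hydroxymethyl)ethyl now each stand apart from two different groups on this nitrogen, rather than from 3-hydroxypropyl alone. Nothing available here accounts for why compounds 3 and 4 read alike despite their different groups.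

The compounds shown leave open whether the carboxy group and the branched isopropyl part of 1-carboxy-2-methylpropyl each matter on their own, which a methyl ester in its place or a straight-chain carboxylic acid would help to separate. They also leave open whether the amine of compound 1 or its shorter chain goes with its lower number, a question that 3-aminopropyl, set against the 3-hydroxypropyl of compound 3, would address directly.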